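This account rests on a few compounds, and the source may have more. Where it says the series, first, only, none or still open, it means among the compounds named here.

Measured so far:
compound 1, `Nc1n[nH]c2cc(-c3ccccn3)[nH]c(=O)c12`: 2%
compound 2, `Cc1cc2c(c(N)nn2C)c(=O)[nH]1`: 11%
compound 3, `Cn1nc(N)c2c(=O)[nH]c(-c3ccccc3)cc21`: 8%

In an assay on isolated protein for inhibition of RAC-alpha serine/threonine-protein kinase (Homo sapiens), read by mobility shift assay, tested at 30 uM (a lower number here means less inhibition, a higher number more inhibition at the concentration tested (going by the name of the read-out)), compound 3 gives 8%. Its number sits among those of compound 2 and compound 1, and every gap between the three numbers lies within the scatter, so the three cannot be told apart on this evidence. Compound 4, `Cn1nc(N)c2c(=O)[nH]c(-c3ccccn3)cc21`, is compound 3 with one change: pyridin-2-yl in place of phenyl on an aromatic carbon. Among the compounds with values here, the only measured step, a number 3 percentage points lower from compound 2 to compound 3 (within the scatter), concerns a different exchange and did not move the read-out beyond the scatter. Within the data shown here, no measured step covers the exchange of phenyl for pyridin-2-yl; the nearest hint is compound 1, which carries pyridin-2-yl on a different core and gives 2%, a low number like the others. With all shown numbers low and close, the step is expected to be a number 2 percentage points lower from compound 3 to compound 4 (within the scatter), nothing beyond the scatter in either direction. Compound 4 is therefore estimated at 6%, in a range from 0% to 18%.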

Compound 4, a percentage reported as inhibition, at one concentration (the size of the read-out at that concentration, not a potency): 7%
Compound 4: the middle estimate sits 1 percentage points below what was measured; low and high end bracket the measured number.
By their numbers in this assay, from the lowest: compounds 1, 4, 3 and 2 (each within the scatter of the next).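

In this assay the exchange of phenyl for pyridin-2-yl on the aromatic carbon next to the ring nitrogen gives a number 1 percentage points lower from compound 3 to compound 4 (within the scatter) and so shows that a ring nitrogen with its hydrogen-bond acceptor does not move the read-out beyond the scatter at this position. Pyridin-2-yl in place of methyl at the same place gives a number 4 percentage points lower from compound 2 to compound 4 (within the scatter) and methyl in place of hydrogen on an aromatic nitrogen gives a number 5 percentage points higher from compound 1 to compound 4 (within the scatter) so neither change separates these compounds on this evidence. Nothing available here offers an explanation for these results. Going by these compounds, whether a group other than methyl or an aromatic ring at this position, such as a carboxylic acid or a longer alkyl chain, would change the inhibition remains open. The compounds shown also leave open whether any change to the shared core would do so.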